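This account rests on a few compounds, and the source may have more. Where it says the series, first, only, none or still open, it means among the compounds named here.

Compound 1 `Cc1cc(-c2cccs2)cc(C)c1Nc1ccnc(Nc2ccc(C#N)cc2)n1`: 10000 nM
Compound 2 `Cc1cc(-c2ccc3cc[nH]c3c2)cc(C)c1Nc1ccnc(Nc2ccc(C#N)cc2)n1`: 5800 nM
Compound 3 `Cc1csc(-c2cc(C)c(Nc3ccnc(Nc4ccc(C#N)cc4)n3)c(C)c2)c1`: 34000 nM

In a toxicity assay on MT4 cells (Homo sapiens) for cytotoxicity, read by MTT assay, with a stated time of 5 days (on this read-out higher numbers stand for lower toxicity in this test and lower numbers for higher toxicity in this test), compound 3 gives 34000 nM, the highest of the three numbers and so the lowest toxicity in this small set. The next change leads to compound 4 `Cc1cc(-c2cc(F)nc(F)c2)cc(C)c1Nc1ccnc(Nc2ccc(C#N)cc2)n1`, with 2,6-difluoropyridin-4-yl in place of 4-methylthiophen-2-yl on an aromatic carbon.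

Going by the values given here, three measured steps bear on this change. Swapping one aromatic group for another has so far moved the number only moderately: a 5.9-fold higher number from compound 2 to compound 3 (0.77 log units; beyond the scatter) is modest, and a 1.7-fold lower number from compound 1 to compound 2 (0.24 log units; within the scatter) stays within the scatter. The methyl in place of hydrogen on an aromatic carbon gives a 3.4-fold higher number from compound 1 to compound 3 (0.53 log units; beyond the scatter), also modest, so even a small edit of this group registers in this assay. Among the compounds with values here, no measured compound carries a pyridine group or fluorine, so the data offer no direct guide to this replacement.

Compound 3 sits at the top of the range, while compound 1 gives 10000 nM and compound 2 gives 5800 nM. A modest move back towards those two values is therefore expected. The expected change is a 2.6-fold lower number from compound 3 to compound 4 (0.42 log units; beyond the scatter). For compound 4 the estimate is 13000 nM, with an expected range from 4500 nM to 38000 nM.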

Compound 4, half-maximal cytotoxic concentration: 6300 nM
Beside the measured number, compound 4's estimate is 2.1-fold (0.31 log units) above it; the range from low to high includes it.
By their numbers in this assay, from the lowest: compounds 2, 4 and 1 (each within the scatter of the next); then compound 3.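

In this assay, going by these compounds alone, the 2,6-difluoropyridin-4-yl group brings a pyridine ring and fluorine onto this aromatic carbon for the first time, and the change gives a 5.4-fold lower number from compound 3 to compound 4 (0.73 log units; beyond the scatter) and so takes away the distinction of compound 3. Against the other two groups the same replacement gives a 1.1-fold higher number from compound 2 to compound 4 (0.04 log units; within the scatter) and a 1.6-fold lower number from compound 1 to compound 4 (0.20 log units; within the scatter) and both stay within the scatter, so thiophen-2-yl, 1H-indol-6-yl and 2,6-difluoropyridin-4-yl cannot be told apart here even though they differ in ring size and atoms, and among the four compounds only compound 3, with its 4-methylthiophen-2-yl group, stands apart. Nothing in the data shown accounts for the gap that separates compound 3 from the others.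

The compounds shown leave open whether a methyl on the pyridine or indole ring would raise the number as it does on the thiophene ring, or whether that rise belongs to compound 3 alone. They also leave open whether an amine or a carboxylic acid on this aromatic carbon would stay with compound 1, compound 2 and compound 4 or move beyond them.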